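The compounds below may be only part of what the source reports. "The series", "measured", "known", "first", "only" and "open" are said of these compounds alone.

Compound 1, `COc1cc(-c2cc(/C=C/C(=O)c3ccc(N)cc3)[nH]n2)cc(OC)c1OC`, was examined in a functional assay on SN12C cells (Homo sapiens) for cytotoxicity, read by sulforhodamine B assay, with a stated time of 48 h, tested at 1 uM (a higher number here means a weaker effect of the compound at the concentration tested, a lower number a stronger effect), where compound 1 gives 85%. Two other compounds were run alongside it. Compound 2, `COc1ccc(-c2cc(/C=C/C(=O)c3cc(OC)c(OC)c(OC)c3)[nH]n2)cc1OC`, gives 87% in this assay, and compound 3, `COc1ccc(-c2cc(/C=C/C(=O)c3ccc(N)cc3)[nH]n2)cc1`, gives 76%. All three numbers lie within the usual scatter of one another, so they cannot be ranked: the number for compound 1 sits closest to that of compound 2, and its widest separation, to compound 3, still stays inside the scatter. Among the measured compounds shown here, no step between these measured compounds can be counted as a real change.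

The next compound, compound 4, `COc1ccc(C(=O)/C=C/c2cc(-c3cc(OC)c(OC)c(OC)c3)n[nH]2)cc1`, is built from compound 1 by a single change: methoxy in place of amino on an aromatic carbon. Since compound 2, which carries no amino group at all, gives 87% and compound 1 gives 85%, there is no sign in these data that the amino group matters for the read-out at this concentration. Compound 4 is therefore expected to behave like compound 1, with a step from compound 1 to compound 4 of no change at the digits printed from compound 1 to compound 4 (within the scatter), not beyond the scatter. The estimate for compound 4 in this assay is 85%, with a range from 68% to 98%.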

Compound 4, a percentage reported as activity, at one concentration (the size of the read-out at that concentration, not a potency): 91%
Compound 4: middle estimate off by 6 percentage points, on the low side, and the stated range covers the measured number.
By their numbers in this assay, from the lowest: compounds 3, 1, 2 and 4 (each within the scatter of the next, the first and the last beyond it).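

The exchange of amino for methoxy, at the place para to a large group on the six-membered aromatic ring, gives a number 6 percentage points higher from compound 1 to compound 4 (within the scatter) in this assay. Among the compounds shown here, earlier comparisons could only set compounds apart that differ in more than one place, so this is the first direct reading of this position: with the core of compound 1 held constant, the 4-aminophenyl and 4-methoxyphenyl forms cannot be told apart at the concentration tested, even though the hydrogen-bond donor of the amino group is gone in compound 4. Nothing measured here offers an explanation of this result.

Still open, from the compounds shown here alone, is whether this position tolerates every group or only these two, since a hydroxyl, a carboxylic acid or a dimethylamino group in the same place could give a different read-out. The result also rests on a single concentration, so it says nothing about whether compound 1 and compound 4 would still match in potency.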